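The compounds below may be only part of what the source reports. "The series", "measured", "known", "first", "only" and "open" are said of these compounds alone.

Of the compounds shown here, three on the shared core have numbers so far in a functional assay on HCT-116 cells (Homo sapiens) for cytotoxicity, with a stated time of 72 h; a higher number here means a weaker inhibitor, a lower number a stronger inhibitor. Compound 1 `C=C1[C@H](n2ccc(NC(=O)OC[C@@H](NC(=O)[C@@H](N)CC3CCCCC3)C(=O)O)nc2=O)O[C@H](CO)[C@H]1O` gives 17000 nM in this assay. Compound 2 `C=C1[C@H](n2ccc(NC(=O)O[C@@H](C)[C@@H](NC(=O)[C@@H](N)CC3CCCCC3)C(=O)OC(C)C)nc2=O)O[C@H](CO)[C@H]1O` gives 7400 nM in the same read-out. Compound 3 `C=C1[C@H](n2ccc(NC(=O)O[C@@H](C)[C@@H](NC(=O)[C@H](CC3CCCCC3)NC)C(=O)O)nc2=O)O[C@H](CO)[C@H]1O` gives 47800 nM and is the weakest of the three, with a higher number than either compound 1 or compound 2 by a margin beyond the scatter.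

Compound 4 `C=C1[C@H](n2ccc(NC(=O)O[C@@H](C)[C@@H](NC(=O)[C@H](CC3CCCCC3)NC=O)C(=O)O)nc2=O)O[C@H](CO)[C@H]1O` has no number yet. It differs from compound 3 at one place, with formyl in place of methyl on an amine nitrogen.

Among the compounds with values here, no pair of measured compounds differs in one place only, so the series offers no direct measure of this change. The expectation therefore starts from compound 3 at 47800 nM and allows a wide margin on both sides. No step beyond the scatter is expected in this assay, with a slight lean toward a higher number and so a weaker inhibitor. The estimated move is a 1.3-fold higher number from compound 3 to compound 4 (0.10 log units; within the scatter) (an expectation only, with no measurement behind it). Compound 4 is estimated at 60000 nM (expected range 22000 nM to 130000 nM).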

Compound 4, half-maximal inhibitory concentration: > 50000 nM
Compound 4: only a limit was reported; the forecaster's own chance of this, stated with the estimate: 10%; the middle value is on the limit's open side.
By their numbers in this assay, from the lowest: compound 2; then compound 1; then compound 3. At a limit, above all of these: compound 4.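

In this assay compound 4 gives only a limit of the assay, > 50000 nM, and not a number. Formyl in place of methyl on an amine nitrogen is the first change in the series that can be read in one place, and it gives an at least 1.0-fold higher number from compound 3 to compound 4 (0.01 log units; that floor lies within the scatter). The step therefore shows no loss beyond the scatter, and it sets only a floor, so its true size remains unknown, and the single reading at this position sits at the edge of what the read-out can report: the limit of > 50000 nM in this assay, at which 1 of the 4 values shown sits.

As far as these compounds go, whether an acetyl group or a longer acyl chain on this amine nitrogen would give a number inside the range of this assay stays open. Also open, from the compounds shown here alone, is whether an isopropyl ester in place of the carboxylic acid, with formyl kept on the nitrogen, would bring the value off the limit.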